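A few compounds are considered here, and "the series" means these few. Any claim that something is new, unique, unknown or untested is made for them only; others in the source may bear on it.

Working notes. a functional assay on the whole organism (Ear, strain ICR) for inhibition, with Mus musculus as the target, with stated times of 30 min and 2 h, at a dose of 10 umol/kg by the oral route (a higher number here means more inhibition at the dose given (going by the name of the read-out), a lower number less inhibition), has two compounds so far. Compound 1, `CC[C@H](C)[C@H](NCCC1OCC(C)(C)CO1)C(=O)N[C@H]1[C@@H](OCc2ccccc2)O[C@H](COCc2ccccc2)[C@@H](OCc2ccccc2)[C@@H]1OCc1ccccc1`, gives 81.6% in this assay. Compound 2, `CC[C@H](C)[C@H](NCCC1OCC(C)(C)CO1)C(=O)N[C@H]1C(O)O[C@H](CO)[C@@H](O)[C@@H]1O`, gives 88.7%, the larger of the two numbers, yet the gap to compound 1 lies within the scatter, so no order between them is claimed. Compound 3, `CC(C)[C@H](NCCC1OCC(C)(C)CO1)C(=O)N[C@H]1C(O)O[C@H](CO)[C@@H](O)[C@@H]1O`, is not yet measured; it differs from compound 2 by hydrogen in place of methyl on a saturated chain carbon, three bonds along the chain from an amine nitrogen and a carbonyl carbon. Going by the values given here, with no measured pair carrying a comparable change, the step is expected to be small and downward at most, a number 8.7 percentage points lower from compound 2 to compound 3 (within the scatter). Compound 3 is estimated at 80% in this assay, with a range from 60% to 95%.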

Compound 3, a percentage reported as inhibition, in the whole organism at one dose (the size of the read-out at that dose, not a potency): 85.1%
The estimate for compound 3 lay 5.1 percentage points below the measured number; low and high end bracket the measured number.
By their numbers in this assay, from the lowest: compounds 1, 3 and 2 (each within the scatter of the next).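

In this assay, going by these compounds alone, the change from sec-butyl to isopropyl gives a number 3.6 percentage points lower from compound 2 to compound 3 (within the scatter) and is the first single-place step readable. At this dose, the read-out therefore does not separate the two side chains, and removing this methyl leaves the step within the scatter. No available evidence bears on the size of this step.

Still open, as far as these compounds go, is whether a longer chain, a cyclohexyl ring or a hydroxymethyl group on this carbon would also stay within the scatter. From the compounds shown here alone, the size of the same change at other doses also remains unknown.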